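Lengthening an Alkyl Chain and Cytotoxicity in Akata Cells

The source may report more compounds than this note shows. Statements on the series, on what has been measured and on what is new or still open speak of the compounds shown alone.

Three compounds have been measured in an ADME assay on Akata cells (Homo sapiens) for cytotoxicity, with a stated time of 7 days; on this read-out lower numbers stand for higher toxicity in this test and higher numbers for lower toxicity in this test:

Compound 1 `Nc1nc(NC2CC2)c2ncn(/C=C3/CC3(CO)CO)c2n1` gives > 20000 nM, a limit of the assay.
Compound 2 `Nc1nc2c(ncn2/C=C2/CC2(CO)CO)c(=O)[nH]1` gives > 20000 nM, a limit of the assay.
Compound 3 `CCCNc1nc(N)nc2c1ncn2/C=C1/CC1(CO)CO` gives > 24000 nM, a limit of the assay.

Compound 3 therefore stands only at a limit in this assay, as do the two other measured compounds. Within the data shown here, the one step between measured compounds that differ in a single place is a step that the two limits leave unreadable from compound 1 to compound 3. Among the measured compounds shown here, because the evidence consists of the limit of > 20000 nM in this assay, at which 2 of the 3 values shown sit, and (the limit of > 24000 nM in this assay, at which 1 of the 3 values shown sits), no step size can be read from the numbers so far.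

Compound 4 `CCCCNc1nc(N)nc2c1ncn2/C=C1/CC1(CO)CO` differs from compound 3 by methyl in place of hydrogen on a saturated chain carbon, three bonds along the chain from a nitrogen on an aromatic ring. For the measured compounds named here, no measured step matches this change, and the only available step is unreadable. With all three measured compounds sitting at a limit, the expectation is that this small addition to the chain leaves compound 4 at a limit as well, so the expected step is a step that the limit leaves unreadable from compound 3 to compound 4, none beyond the scatter. Compound 4 is therefore estimated at 30000 nM in this assay, with a range from 10000 nM to 100000 nM.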

Compound 4, half-maximal cytotoxic concentration: > 24000 nM
Compound 4 was reported as a limit; the forecaster's own chance of this, stated with the estimate: 85%; the middle value is on the limit's open side.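

Compound 1, compound 3 and compound 4 all stand at limits of the assay rather than at numbers, and neither the step from compound 3 to compound 4 nor the step from compound 1 to compound 4 can be read. The compounds shown leave open at what concentration any of them becomes toxic in this assay, and whether going from propyl to butyl changes that at all.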